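This account rests on a few compounds, and the source may have more. Where it says the series, first, only, none or still open, it means among the compounds named here.

Measured in a functional assay on K562 cells (Homo sapiens) for inhibition, read by sulforhodamine B assay, with a stated time of 48 h, tested at 50 uM; a higher number here means more inhibition of growth at the concentration tested, a lower number less inhibition of growth:
- compound 1 `O=C(Nc1cn2cc(I)ccc2n1)C(F)(F)F`: 33.1%
- compound 2 `O=C(c1ccc(C(F)(F)F)c(F)c1)c1ccc2nc(NC(=O)C(F)(F)F)cn2c1`: 50.1%

Compound 2 stands highest of the two at 50.1%, and compound 1 gives 33.1%. The gap between these two values lies beyond the scatter. Compound 3 `Cc1ccc(C(=O)c2ccc3nc(NC(=O)C(F)(F)F)cn3c2)cc1F` carries methyl in place of trifluoromethyl on an aromatic carbon, ortho to a fluoro group and para to a large group (methyl in place of trifluoromethyl on an aromatic carbon). Going by the values given here, no measured pair shows what this change does in this assay, so only a small fall, possibly none beyond the scatter, is expected. The expected change is a number 4.1 percentage points lower from compound 2 to compound 3 (within the scatter). Compound 3 is estimated at 46%, within a range of 30% to 62%.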

Compound 3, percent growth inhibition at one concentration: 52.2%
Compound 3: the middle estimate sits 6.2 percentage points below what was measured; low and high end bracket the measured number.
By their numbers in this assay, from the lowest: compound 1; then compounds 2 and 3 (each within the scatter of the next).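

In this assay, methyl in place of trifluoromethyl on this aromatic carbon, ortho to a fluoro group and para to a large group, gives a number 2.1 percentage points higher from compound 2 to compound 3 (within the scatter). Going by these compounds alone, this is the first pair to test the position, and it shows that the exchange leaves the reading within the scatter. No measurement at hand bears on why the two compounds read alike.

As far as these compounds go, whether a chlorine, a methoxy group or an amine on this carbon would read the same remains open. A single pair also leaves open whether the exchange would behave alike without the neighbouring fluoro group.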